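This account rests on a few compounds, and the source may have more. Where it says the series, first, only, none or still open, it means among the compounds named here.

Compound 1, `COc1ccc(-c2cc(C(C)=O)c3[nH]c(-c4ccccc4)cc3c2)cc1`: in a functional assay on MCF7 cells (Homo sapiens) for cytotoxicity, read by MTT assay, with a stated time of 2 days (on this read-out lower numbers stand for higher toxicity in this test and higher numbers for lower toxicity in this test), compound 1 gives 47800 nM
Compound 2, `COc1ccc(-c2cc(C(C)=O)c3[nH]c(-c4ccc(F)cc4)cc3c2)cc1`: in this assay compound 2 gives 16800 nM
Compound 3, `COc1ccc(-c2cc(C(C)=O)c3[nH]c(-c4ccc(OC)cc4)cc3c2)cc1`: in this assay compound 3 gives 25200 nM

Of these three numbers, compound 1 gives the highest. Its nearest neighbour is reached by a 1.9-fold lower number from compound 1 to compound 3 (0.28 log units; within the scatter), its furthest by a 2.8-fold lower number from compound 1 to compound 2 (0.45 log units; beyond the scatter), the latter being a modest step. Compound 4, `CC(=O)c1cc(/C=C/c2ccc(F)cc2)cc2cc(-c3ccccc3)[nH]c12`, differs from compound 1 in one place: 2-(4-fluorophenyl)ethenyl in place of 4-methoxyphenyl on an aromatic carbon. For the measured compounds named here, none of the measured steps touches this part of the shared core; all three alter the other phenyl ring, and a 1.5-fold higher number from compound 2 to compound 3 (0.18 log units; within the scatter) shows how little that ring's substituent matters. Only the fluorine entering compound 4 has any parallel, because a 2.8-fold lower number from compound 1 to compound 2 (0.45 log units; beyond the scatter) also brought a fluorine in. A modest lowering of the number is therefore expected, namely a 1.7-fold lower number from compound 1 to compound 4 (0.23 log units; within the scatter). For compound 4 the estimated value is 28000 nM, within a range of 8000 nM to 100000 nM.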

Compound 4, concentration lethal to 50% of the cells: 18500 nM
Beside the measured number, compound 4's estimate is 1.5-fold (0.18 log units) above it, and the stated range covers the measured number.
By their numbers in this assay, from the lowest: compounds 2, 4, 3 and 1 (each within the scatter of the next, the first and the last beyond it).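

For the compounds shown here, the earlier compounds changed only the other phenyl ring, so this is the first sign that this position on the shared core also shifts the number in this assay: 2-(4-fluorophenyl)ethenyl in place of 4-methoxyphenyl gives a 2.6-fold lower number from compound 1 to compound 4 (0.41 log units; beyond the scatter) and keeps the toxicity at least as high as that of compound 1. Nothing measured here explains this step.
From the compounds shown here alone, it remains open whether the double bond or the fluorine carries the step, and how an amine or a carboxylic acid would behave at this position.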